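From Methoxycarbonyl to Methylcarbamoyl in a Cell Assay

The source may hold more compounds than are shown below. What is called first, only, known or untested is meant among the compounds shown, and "the series" means these compounds.

Compound 1 `COC(=O)/C=C/[C@H]1C[C@@H](O)[C@@H](O)C1` was examined in an ADME assay on S2 cells (Drosophila melanogaster) for cytotoxicity, read by MTT assay (on this read-out lower numbers stand for an effect already at smaller amounts and higher numbers for an effect only at larger amounts of compound), where compound 1 gives only a limit of the assay, > 350000 nM. Compound 2 `CCCCCCOC(=O)/C=C/[C@H]1C[C@@H](O)[C@@H](O)C1` likewise gives only a limit in this assay, > 350000 nM. The step that the two limits leave unreadable from compound 1 to compound 2 cannot be read, because of the limit of > 350000 nM in this assay, at which 2 of the 2 values shown sit. Compound 3 `CNC(=O)/C=C/[C@H]1C[C@@H](O)[C@@H](O)C1` differs from compound 1 by methylamino in place of methoxy on a carbonyl carbon. For the measured compounds named here, no measured step bears on this change, and the one known step carries no readable size. Compound 3 is therefore expected to show no readable step either, a number no higher from compound 1 to compound 3 (the limit leaves the size open). The estimate for compound 3 is 350000 nM, with a range from 120000 nM to 1000000 nM.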

Compound 3, half-maximal effective concentration: > 250000 nM
Compound 3: only a limit was reported (the forecaster's own chance of this, stated with the estimate: 85%); the middle value lies beyond the limit too.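

For the compounds shown here, compound 1 and compound 3 each give only a limit in this assay, so no step between them can be read. The compounds shown leave open whether methylamino in place of methoxy changes cytotoxicity at all.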